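One double bond redrawn in the pentyl compound

The compounds below may be only part of what the source reports. "The series", "measured", "known", "first", "only" and "open" are said of these compounds alone.

Values so far in a physicochemical assay for lipophilicity, measured as octanol-water partition (a lower number here means a more polar compound, a higher number a more lipophilic compound), are these:
- compound 1 `COC(=O)c1cn(C/C=C(/C)CC/C=C(\C)CCC=C(C)C)nn1` gives 5.25
- compound 2 `CCCCCc1cn(C/C=C(/C)CC/C=C(\C)CCC=C(C)C)nn1` gives 7.5
- compound 3 `CCCc1cn(C/C=C(/C)CC/C=C(\C)CCC=C(C)C)nn1` gives 6.5

Compound 2 has the highest number of the three. Its measured steps are a number 2.25 log units higher from compound 1 to compound 2 (beyond the scatter) and a number 1.00 log units lower from compound 2 to compound 3 (beyond the scatter) and both are clear moves. The remaining step, a number 1.25 log units higher from compound 1 to compound 3 (beyond the scatter) likewise, also comes from changing the group on an aromatic carbon.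

Compound 4 `CCCCCc1cn(C/C=C(\C)CC/C=C(\C)CCC=C(C)C)nn1` is a different kind of change, since the two compounds have the same atoms and bonds and differ only in configuration as drawn: 1 of 2 stereo elements differ; a double bond is drawn Z in compound 2 and E in compound 4 and no group leaves or enters. Among the measured compounds shown here, none of the measured steps tests a change of this kind, so they give no size to carry over. The starting point is therefore compound 2 at 7.5 with no shift expected beyond the scatter. The estimated change is no change at the digits printed from compound 2 to compound 4 (within the scatter) in this assay and no direction is favoured. For compound 4 the expected value is 7.5 with an estimated range from 7.1 to 7.9 as the likely span.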

Compound 4, partition coefficient: 7.5
Estimate against measurement, compound 4: no gap at the digits printed, within the range that was stated.
By their numbers in this assay, from the lowest: compound 1; then compound 3; then compounds 2 and 4 (each within the scatter of the next).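

In this assay, redrawing this one double bond from Z to E gives no change at the digits printed from compound 2 to compound 4 (within the scatter). Among the compounds shown here, every earlier step changed the group on an aromatic carbon, so this is the first reading of a change in configuration at this double bond, and it is a small result beside those earlier moves. The pair gives an unusually clean comparison, since no group leaves or enters and only this double bond can account for any difference: the fact that compounds 2 and 4 differ only in the configuration as drawn.

As far as these compounds go, this single pair carries pentyl on the aromatic carbon, so it remains open whether the same redrawing would read the same with propyl, methoxycarbonyl, an amine or a carboxylic acid there. From the compounds shown here alone, the second stereo element, the other double bond drawn with a configuration, stays the same in both compounds, so what redrawing it would do also remains open.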